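Ketoamide analogues at the assay limit

The source may hold more compounds than are shown below. What is called first, only, known or untested is meant among the compounds shown, and "the series" means these compounds.

Measured compounds:
Compound 1, `CCOC(=O)C(F)(F)C(O)CCc1ccccc1`: > 10000 nM
Compound 2, `O=C(CCc1ccc(Cl)cc1)C(=O)N1CCCCC1`: > 10000 nM

Of the compounds shown here, two have been measured in an assay on HEK-293T cells for inhibition of phospholipase A and acyltransferase 2 (Homo sapiens), with stated times of 30 min and 20 min; a lower number here means a stronger inhibitor, a higher number a weaker inhibitor. Compound 1 returns only a limit of the assay, > 10000 nM, and no number. Compound 2 likewise returns only a limit, > 10000 nM, so its true value is not known. Nothing places compound 2 on a scale at all: both values shown in this assay are limits, and (the limit of > 10000 nM in this assay, at which 2 of the 2 values shown sit). Among the measured compounds shown here, no pair of measured compounds that differ in one place is available, so no step has been measured.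

Compound 3, `CN(C)C(=O)C(=O)CCc1ccc(Cl)cc1`, has not yet been measured. It differs from compound 2 in one place: dimethylamino in place of piperidin-1-yl on a carbonyl carbon. For the measured compounds named here, with no measured step to lean on and with compound 2 sitting at a limit, the expected step from compound 2 to compound 3 is a step that the limit leaves unreadable from compound 2 to compound 3, that is, none beyond the usual scatter, in either direction. Compound 3 is therefore expected to give about 15000 nM in this assay, within a range of 5000 nM to 50000 nM, most probably reported again only as a limit.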

Compound 3, half-maximal inhibitory concentration: > 10000 nM
Compound 3: only a limit was reported; the forecaster's own chance of this, stated with the estimate: 85%; the middle value is on the limit's open side.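

Compound 2 and compound 3 both return only a limit in this assay, so the step between them, dimethylamino in place of piperidin-1-yl on a carbonyl carbon, cannot be read. The compounds shown leave open how strongly any of them inhibits, and which change would give a readable value: the limit of > 10000 nM in this assay, at which 3 of the 3 values shown sit.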